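Compound 1 to compound 3: hexyl on the chain

The source may report more compounds than this note shows. Statements on the series, on what has been measured and on what is new or still open speak of the compounds shown alone.

In an ADME assay on cells (Epithelial cell, Homo sapiens) for cytotoxicity, read by MTT assay (a higher number here means that more compound is needed for the effect, a lower number that less compound is needed), compound 1 `CCCCCCCCCCCCCCCCNC(=O)NC(CCC(=O)O)(CCC(=O)O)CCC(=O)O` gives 350000 nM and compound 2 `CCCCCCCCCCCCCCCCCCCC(=O)NC(CCC(=O)O)(CCC(=O)O)CCC(=O)O` gives 340000 nM. These two values lie within the scatter of each other, so compound 1 stands level with compound 2. Compound 3 `CCCCCCCCCCCCCCCCCCCCCCNC(=O)NC(CCC(=O)O)(CCC(=O)O)CCC(=O)O` carries hexyl in place of hydrogen on a saturated chain carbon, ten or more bonds along the chain from an amide-type nitrogen. Going by the values given here, no measured pair shows this change alone, so the expectation is loose. A modest move to a lower number in this assay is expected, perhaps little beyond the scatter. The expected step is a 1.8-fold lower number from compound 1 to compound 3 (0.24 log units; within the scatter). Compound 3 is estimated at 200000 nM, within a range of 60000 nM to 500000 nM.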

Compound 3, half-maximal effective concentration: 260000 nM
Beside the measured number, compound 3's estimate is 1.3-fold (0.11 log units) below it; the range from low to high includes it.
By their numbers in this assay, from the lowest: compounds 3, 2 and 1 (each within the scatter of the next).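

Hexyl in place of hydrogen on a saturated chain carbon gives a 1.3-fold lower number from compound 1 to compound 3 (0.13 log units; within the scatter) in this assay. Going by these compounds alone, this is the first single-change step, and it shows that this much added chain length on the urea-bearing compound 1 leaves the reading within the scatter. Nothing measured here accounts for the result.

Still open, as far as these compounds go, is whether a much longer chain, or a carboxylic acid or an amine at the end of the chain, would move the number beyond the scatter.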